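The source may report more compounds than this note shows. Statements on the series, on what has been measured and on what is new or still open speak of the compounds shown alone.

Compound 1 `CC1=C(CN2CC(C(=O)O)C2)CCc2cc(OCCC3CCc4ccccc43)ccc21`: > 1 mg/kg, a limit and not a number.
Compound 2 `COc1cc(CC(C)C)ccc1COc1ccc2c(c1)CCC(CN1CC(C(=O)O)C1)=C2C`: 0.0092 mg/kg.

Within the data shown here, in a functional assay on the whole organism (strain BALB/c) with Mus musculus as the target, with a stated time of 4 h (on this read-out lower numbers stand for an effect already at smaller amounts and higher numbers for an effect only at larger amounts of compound), compound 2 gives 0.0092 mg/kg, the only true number so far. The reading for compound 1 is only a limit, so it gives no measured gap to compound 2 and no scale for the next step.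

Compound 3 `COc1cc(C)ccc1COc1ccc2c(c1)CCC(CN1CC(C(=O)O)C1)=C2C` keeps the core of compound 2 and has hydrogen in place of isopropyl on a saturated chain carbon bound to an aromatic carbon. Cut one bond further out, this reads isobutyl to methyl.

Among the measured compounds shown here, no measured step covers this change, so the following is a judgement with wide margins. The expected size is a 5.4-fold higher number from compound 2 to compound 3 (0.74 log units; beyond the scatter), a rise in dose beyond the scatter. For compound 3 the estimated value is 0.05 mg/kg, with an expected range of 0.012 mg/kg to 0.3 mg/kg.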

Compound 3, dose for half-maximal effect: > 0.1 mg/kg
Compound 3 gave a limit, no number; the forecaster's own chance of this, stated with the estimate: 15%; middle value at least 2.0-fold (0.30 log units) from the limit.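

In this assay, hydrogen in place of isopropyl on a saturated chain carbon bound to an aromatic carbon, or isobutyl to methyl when cut one bond further out, gives an at least 10-fold higher number from compound 2 to compound 3 (1.03 log units; beyond the scatter). Among these compounds, this is the first readable step, and it shows that the low dose of compound 2 does not survive this change on the shared core. The reading for compound 3 is a limit and not a number: the limit of > 0.1 mg/kg in this assay, at which 1 of the 3 values shown sits.

On these data alone, the true size of the step therefore stays open, and the steps that rest on two limits cannot be read. As far as these compounds go, it also remains open whether ethyl, propyl or a longer chain at this place would bring the reading back towards compound 2, at 0.0092 mg/kg, or whether a cyclopropylmethyl group would serve in place of isobutyl.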